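Hydroperoxide-type replacement in a diterpenoid pair for PC-3 growth inhibition

This account rests on a few compounds, and the source may have more. Where it says the series, first, only, none or still open, it means among the compounds named here.

Of the compounds shown here, two have numbers so far. Compound 1 `Cc1cc2c(C(C)C)ccc(C)c2cc1O` is the aromatic reference; in a functional assay on PC-3 cells (Homo sapiens) for inhibition, read by colorimetric assay and MTT assay (on this read-out higher numbers stand for weaker inhibition of growth and lower numbers for stronger inhibition of growth), compound 1 gives 54000 nM. Compound 2 `C=C/C(C)=C/C[C@H]1C(=C)CC[C@H]2[C@](C)(CO)CCC[C@]12C`, a bicyclic diterpenoid with a hydroxymethyl on the ring, gives 35000 nM in this assay. Compound 2 holds the lowest of the two numbers, but its nearest neighbour, compound 1, sits within the scatter, so no order between them can be read.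

Compound 3 `C=CC(=C)[C@@H](C[C@H]1C(=C)CC[C@H]2[C@](C)(CO)CCC[C@]12C)OO` is the next member. Compared with compound 2 the change is a group of 7 heavy atoms (5 carbon, 2 oxygen; no ring) in place of a group of 5 heavy atoms (5 carbon; no ring), on a saturated chain carbon bound to a saturated ring carbon. Among the measured compounds shown here, no step between measured compounds of this kind is available, so the direction rests on the structural change alone: the entering group carries hydrogen-bond donor and acceptor atoms where the leaving diene had none.

For compound 3 in this assay a modest gain in growth inhibition is expected, the step of a 2.9-fold lower number from compound 2 to compound 3 (0.46 log units; beyond the scatter) estimated to be somewhat beyond the scatter but not large. Compound 3 is thus estimated at 12000 nM, with a range from 4000 nM to 40000 nM.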

Compound 3, concentration for 50% growth inhibition: 34400 nM
Compound 3: middle estimate off by 2.9-fold (0.46 log units), on the low side, and the stated range covers the measured number.
By their numbers in this assay, from the lowest: compounds 3, 2 and 1 (each within the scatter of the next).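

In this assay, the replacement of 2-methylbuta-1,3-dien-1-yl by the hydroperoxide-bearing group gives a 1.0-fold lower number from compound 2 to compound 3 (0.01 log units; within the scatter). This first step at this place, on a saturated chain carbon bound to a saturated ring carbon, shows that the entry of hydrogen-bond donor and acceptor atoms is accompanied by no readable shift in growth inhibition. No measurement that could account for this result is available.

This single step cannot show whether the place is generally insensitive to change, since other groups could behave differently. A carboxylic acid, an amine or a longer chain at this place remains untested in the compounds shown here, as does the opposite configuration at the defined stereocentre of the entering group.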